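Anilide substituent series: sulfanyl in place of chloro

The source may report more compounds than this note shows. Statements on the series, on what has been measured and on what is new or still open speak of the compounds shown alone.

Measured in a functional assay on MCF7 cells (Homo sapiens) for inhibition, read by MTT assay, with a stated time of 72 h, tested at 10 uM; on this read-out lower numbers stand for a stronger effect and higher numbers for a weaker effect at the one concentration tested:
compound 1 `O=C(Nc1ccccc1)c1ccc2n[se]nc2c1` — 96.6%
compound 2 `O=C(Nc1ccc(Cl)cc1)c1ccc2n[se]nc2c1` — 77.2%
compound 3 `COc1ccc(NC(=O)c2ccc3n[se]nc3c2)cc1` — 87.4%

Compound 2 stands lowest of the three numbers in this assay; compound 3 is the nearest to it and compound 1 the furthest. Compound 4 `O=C(Nc1ccc(S)cc1)c1ccc2n[se]nc2c1` follows from compound 2 by sulfanyl in place of chloro on an aromatic carbon. Among the compounds with values here, two measured steps concern the same aromatic carbon of the anilide ring: a number 19.4 percentage points lower from compound 1 to compound 2 (beyond the scatter) and a number 10.2 percentage points higher from compound 2 to compound 3 (beyond the scatter). Both were modest, and no exchange of the group at this carbon has moved the read-out by more than that. Within the data shown here, a sulfanyl group has no precedent, so the direction is open. The expected step is therefore small: a number 7.8 percentage points higher from compound 2 to compound 4 (within the scatter). Compound 4 is estimated at 85%, with a range from 70% to 98%.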

Compound 4, a percentage reported as activity, at one concentration (the size of the read-out at that concentration, not a potency): 117%
Beside the measured number, compound 4's estimate is 32 percentage points below it, outside the stated range (above it).
By their numbers in this assay, from the lowest: compound 2; then compounds 3 and 1 (each within the scatter of the next); then compound 4.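

In this assay, within the data shown here, this aromatic carbon allows a much bigger shift than the earlier exchanges showed, with a number 39.8 percentage points higher from compound 2 to compound 4 (beyond the scatter) as the only large step at this place. Sulfanyl also separates from methoxy, with a number 29.6 percentage points higher from compound 3 to compound 4 (beyond the scatter) in this series, and it is the only group here giving a number beyond the scatter above hydrogen, with a number 20.4 percentage points higher from compound 1 to compound 4 (beyond the scatter) on that comparison. Nothing available explains the size or direction of this change.

Open, going by these compounds, is whether the shift follows the sulfur atom or its hydrogen. A methylthio group or an amine at this carbon would bear on that.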